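A few compounds are considered here, and "the series" means these few. Any claim that something is new, unique, unknown or untested is made for them only; others in the source may bear on it.

Compound 1 `CN(C)S(=O)(=O)c1ccc(F)c(C#Cc2cc(Cl)ccc2OCC(=O)O)c1` gives 23 nM in a functional assay on cells for antagonist activity at prostaglandin D2 receptor 2 (Homo sapiens), read by flow cytometry, with a stated time of 10 min; a lower number here means a stronger inhibitor, a higher number a weaker inhibitor; compound 2 `COCCN(C)S(=O)(=O)c1ccc(C)c(C#Cc2cc(Cl)ccc2OCC(=O)O)c1` gives 77 nM; compound 3 `Cc1ccc(S(=O)(=O)N(C)C(C)C)cc1C#Cc1cc(Cl)ccc1OCC(=O)O` gives 140 nM.

Compound 3 carries the highest of the three numbers. Its nearest neighbour is compound 2: the change from 2-methoxyethyl to isopropyl on the sulfonamide nitrogen gave a 1.8-fold higher number from compound 2 to compound 3 (0.26 log units; within the scatter), a step within the scatter. Among the compounds with values here, compound 1, which gives 23 nM, lies furthest from compound 3, and that gap is beyond the scatter; no single-point step links those two.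

Compound 4 `COCCNS(=O)(=O)c1ccc(C)c(C#Cc2cc(Cl)ccc2OCC(=O)O)c1` is the next compound. It differs from compound 3 by (2-methoxyethyl)amino in place of isopropyl(methyl)amino on a sulfonyl sulfur. Within the data shown here, only one measured step bears on this change: the swap between 2-methoxyethyl and isopropyl seen in a 1.8-fold higher number from compound 2 to compound 3 (0.26 log units; within the scatter), which covers the carbon chain but not the loss of the methyl group from the sulfonamide nitrogen, for which no measured pair exists. Since compound 2 gives 77 nM with the same 2-methoxyethyl chain, compound 4 is expected to land close to compound 2, so that the estimated step is a 1.6-fold lower number from compound 3 to compound 4 (0.19 log units; within the scatter), no larger than the scatter. The estimate for compound 4 is 90 nM, with a range of 35 nM to 250 nM.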

Compound 4, half-maximal inhibitory concentration: 88 nM
Estimate against measurement, compound 4: 1.0-fold (0.01 log units) above; measured number inside the range.
By their numbers in this assay, from the lowest: compound 1; then compounds 2, 4 and 3 (each within the scatter of the next).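

Within the data shown here, with the 2-methoxyethyl chain held constant, the step of a 1.1-fold higher number from compound 2 to compound 4 (0.06 log units; within the scatter) gives the first measured reading for hydrogen in place of methyl on the sulfonamide nitrogen, and in this assay this exchange stays within the scatter. The second step, a 1.6-fold lower number from compound 3 to compound 4 (0.20 log units; within the scatter), changes the chain and the methyl together, replacing isopropyl(methyl)amino with (2-methoxyethyl)amino and adding the hydrogen-bond donor and oxygen counted for the entering group, yet it too stays within the scatter; thus none of the three steps among compounds 2, 3 and 4 goes beyond it, although no reason for this can be offered, as nothing beyond these numbers bears on the result.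

The compounds shown leave open whether hydrogen in place of methyl would read the same with an isopropyl group on the sulfonamide nitrogen, since the only measured pair for that exchange carries 2-methoxyethyl. They also leave open how a morpholine ring on the sulfonyl sulfur, or a carboxylic acid or a longer chain on the sulfonamide nitrogen, would read in this assay.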